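The source may report more compounds than this note shows. Statements on the series, on what has been measured and on what is new or still open speak of the compounds shown alone.

Measured so far:
- compound 1 `COc1ccc(/C(=N/O)c2cccc3ccccc23)c(OC)c1OC` — a functional assay on HCT-116 cells (Homo sapiens) for inhibition, read by sulforhodamine B assay, with a stated time of 48 h; on this read-out lower numbers stand for stronger inhibition and higher numbers for weaker inhibition: 5880 nM
- compound 2 `COc1ccc(C(c2ccc(OCCO)cc2)c2cccc3ccccc23)c(OC)c1OC` — this assay : > 20000 nM

Compound 1 stands on the only number shown in this assay, the half-maximal inhibitory concentration of 5880 nM. The one other entry in this assay, that of compound 2, is a limit rather than a number. Compound 2 returns only a limit in this assay, > 20000 nM, and that reading is the limit of > 20000 nM in this assay, at which 1 of the 2 values shown sits. Among the measured compounds shown here, compound 2 and compound 1 differ in several places at once, so no single step can be drawn between them; the two values show only that compound 2 lies at the limit while compound 1 gives a number.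

Compound 3 `CCOC(=O)/C=C/CO/N=C(/c1ccc(OC)c(OC)c1OC)c1cccc2ccccc12` is not yet measured. It differs from compound 1 in one place: 3-(ethoxycarbonyl)prop-2-en-1-yl in place of hydrogen on an oxygen. For the measured compounds named here, no step between measured compounds covers a change of this kind, so the direction has to be guessed. Alkylation of the oxime oxygen with a chain of this size is expected to cost some activity, a step from compound 1 to compound 3 of a 1.5-fold higher number from compound 1 to compound 3 (0.18 log units; within the scatter), at or just beyond the scatter. Compound 3 is therefore estimated at 9000 nM, with a range from 2500 nM to 30000 nM.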

Compound 3, half-maximal inhibitory concentration: > 20000 nM
Compound 3 was reported as a limit; the forecaster's own chance of this, stated with the estimate: 25%; at least 2.2-fold (0.34 log units) between middle value and limit.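

Among the compounds shown here, this is the first step that can be read at this position: with 3-(ethoxycarbonyl)prop-2-en-1-yl in place of the hydrogen on the oxygen whose other neighbour is a double-bonded nitrogen, this assay shows an at least 3.4-fold higher number from compound 1 to compound 3 (0.53 log units; beyond the scatter), and this change lies beyond the scatter. On these data alone, compound 3 gives > 20000 nM, which is a limit of the assay and not a number, so the true size of the step stays unknown and only its minimum is fixed. Compound 1, with the free hydroxy group at this position, remains the only compound that returns a number, while the others sit at the limit: the limit of > 20000 nM in this assay, at which 2 of the 3 values shown sit.

The compounds shown leave open whether the loss follows from any substituent on this oxygen or from this particular chain with its ethyl ester. A simple methyl group on the same oxygen, or a shorter chain carrying a carboxylic acid or an amine, would separate these readings, and a value below the limit for any of them would allow a measured step from compound 1.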